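The source may hold more compounds than are shown below. What is called first, only, known or untested is meant among the compounds shown, and "the series" means these compounds.

Measured compounds:
- compound 1 `COc1ccc(NC(=O)NCC2(c3ccccc3)CCCCC2)cc1`: 4900 nM
- compound 2 `CC(C)c1ccc(NC(=O)NCC2(c3ccccc3)CCCCC2)cc1`: 1500 nM
- compound 3 `CCOC(=O)c1ccc(NC(=O)NCC2(c3ccccc3)CCCCC2)cc1`: 6100 nM

In an assay on microsomes from intestine for inhibition of acyl-CoA:cholesterol acyltransferase (Oryctolagus cuniculus) (a lower number here means a stronger inhibitor, a higher number a weaker inhibitor), compound 1 sits second highest of the three numbers. Its nearest neighbour is compound 3, with a 1.2-fold higher number from compound 1 to compound 3 (0.10 log units; within the scatter), a gap within the scatter, so no order between these two can be read. The furthest is compound 2, with a 3.3-fold lower number from compound 1 to compound 2 (0.51 log units; beyond the scatter), a modest step beyond the scatter; the same pairing is seen again in a 4.1-fold higher number from compound 2 to compound 3 (0.61 log units; beyond the scatter).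

The next compound, compound 4 `O=C(NCC1(c2ccccc2)CCCCC1)Nc1ccc(Cl)c(Cl)c1`, differs from compound 1 in one place: 3,4-dichlorophenyl in place of 4-methoxyphenyl on an amide-type nitrogen. Neither measured step repeats this change. The two steps that start from compound 1 show what an exchange of the group on the aryl ring can do in this assay: one swap left the number essentially unchanged, the other lowered it modestly. All three measured numbers lie within a narrow band, and nothing among them points to a large move in either direction.

On that basis compound 4 is expected to fall inside the same band, most likely with a modest lowering, a 2.0-fold lower number from compound 1 to compound 4 (0.29 log units; within the scatter), giving an estimate of 2500 nM with a range from 800 nM to 8000 nM.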

Compound 4, half-maximal inhibitory concentration: 3800 nM
For compound 4 the middle estimate is 1.5-fold (0.18 log units) below the measured one; low and high end bracket the measured number.
By their numbers in this assay, from the lowest: compound 2; then compounds 4, 1 and 3 (each within the scatter of the next).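

In this assay, the exchange on the amide-type nitrogen now extends to a ring carrying two chlorine atoms: 3,4-dichlorophenyl in place of 4-methoxyphenyl gives a 1.3-fold lower number from compound 1 to compound 4 (0.11 log units; within the scatter). The entering group has no hydrogen-bond acceptor where the leaving group has one, and this loss produces no readable change in the number, so the oxygen of the methoxy group is not required to hold the level of compound 1 in this comparison. No measurement is available that would explain why this exchange leaves the number within the scatter.

Compound 2, at 1500 nM, keeps its isopropyl group as the only aryl substituent shown whose step from compound 1 lies beyond the scatter, and it remains open whether a tert-butyl group or a longer alkyl chain would extend that step, or whether an amine or a carboxylic acid on the ring would reverse it. Also open, on these data alone, are the separate contributions of the two chlorine atoms, since a ring with a single chlorine does not appear here, and any exchange in the shared core away from the aryl group.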